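Three Methoxy Groups in Place of One on the Benzamide

A few compounds are considered here, and "the series" means these few. Any claim that something is new, unique, unknown or untested is made for them only; others in the source may bear on it.

Compound 1 `Cc1ccc(Nc2ncc(C(=O)Nc3cc(NC(=O)c4cccc(C(F)(F)F)c4)ccc3C)cn2)cc1N`, compound 2 `CNc1nc(Nc2ccc(C)c([N+](=O)[O-])c2)ncc1C(=O)Nc1cc(NC(=O)c2cccc(OC)c2)ccc1C` and compound 3 `CNc1nc(Nc2ccc(C)c(N)c2)ncc1C(=O)Nc1cc(NC(=O)c2cccc(OC)c2)ccc1C` share one core and differ at the aniline and at the aryl amide. In an ADME assay on BaF3 cells (Mus musculus) for antiproliferative activity, read by CellTiter-Glo and CCK-8 assay, with a stated time of 72 h (on this read-out lower numbers stand for stronger inhibition of growth and higher numbers for weaker inhibition of growth), compound 2 gives 6310 nM. Compound 1 gives > 10000 nM, which is a limit of this assay and not a number. Compound 3 gives > 10000 nM, again a limit. Among the compounds with values here, the single measured step, an at least 1.5-fold higher number from compound 2 to compound 3 (0.19 log units; that floor lies within the scatter), concerns the aniline only and has a floor within the scatter; compound 3 thus stands at the limit of > 10000 nM in this assay, at which 2 of the 3 values shown sit, with no number to place it.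

Compound 4 `CNc1nc(Nc2ccc(C)c(N)c2)ncc1C(=O)Nc1cc(NC(=O)c2cc(OC)c(OC)c(OC)c2)ccc1C` differs from compound 3 by 3,4,5-trimethoxyphenyl in place of 3-methoxyphenyl on a carbonyl carbon. Within the data shown here, no measured step touches the aryl amide, so none bears on this change and no direction can be drawn from the data for this assay. With compound 3 resting at the limit, compound 4 is expected to give about 15000 nM, estimated between 4000 nM and 60000 nM. The expected step that the limit leaves unreadable from compound 3 to compound 4 is accordingly estimated as none beyond the scatter, and most likely another limit.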

Compound 4, concentration for 50% growth inhibition: > 10000 nM
Compound 4: no number, only a limit; the forecaster's own chance of this, stated with the estimate: 70%; the middle value lies beyond the limit too.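

In this assay compound 4 gives > 10000 nM, a limit and not a number. Compound 3 also sits at a limit, so no step from compound 3 to compound 4 can be read: the limit of > 10000 nM in this assay, at which 3 of the 4 values shown sit.

The compounds shown leave open whether 3,4,5-trimethoxyphenyl in place of 3-methoxyphenyl on a carbonyl carbon changes growth inhibition at all.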